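Vinyl in place of methyl: working notes

The compounds below may be only part of what the source reports. "The series", "measured", "known", "first", "only" and "open" are said of these compounds alone.

Measured in a functional assay on A-431 cells (Homo sapiens) for cytotoxicity; a lower number here means that less compound is needed, a higher number that more compound is needed for the effect:
compound 1 `COC1=C(C)C(=O)/C(=C(O)/C=C/c2ccc(F)cc2)C(=O)C1(C)C`: 4.1 ug/mL
compound 2 `COC1=C(C)C(=O)/C(=C(O)/C=C/c2ccc(C)cc2)C(=O)C1(C)C`: 5.1 ug/mL
compound 3 `COC1=C(C)C(=O)/C(=C(O)/C=C/c2ccccc2C)C(=O)C1(C)C`: 5.2 ug/mL

In this assay compound 3 gives 5.2 ug/mL, which sits within the scatter of both other compounds. The two steps that reach it are a 1.0-fold higher number from compound 2 to compound 3 (0.01 log units; within the scatter) and a 1.3-fold higher number from compound 1 to compound 3 (0.10 log units; within the scatter).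

The unmeasured compound 4 `C=Cc1ccccc1/C=C/C(O)=C1/C(=O)C(C)=C(OC)C(C)(C)C1=O` keeps the core of compound 3 and changes only the aromatic substituent: vinyl in place of methyl on an aromatic carbon. In words, this is vinyl in place of methyl on an aromatic carbon, or 2-methylphenyl to 2-vinylphenyl.

Among the compounds with values here, no measured compound carries a vinyl group, so no step shows this exchange directly. The nearest evidence is the set of changes on the same aromatic ring. Besides the two steps above, there is a 1.2-fold higher number from compound 1 to compound 2 (0.09 log units; within the scatter), with methyl in place of fluoro. All three stay within the scatter, so the three compounds give no sign of sensitivity to these changes. Going by these steps, no step beyond the scatter is expected in this assay, and no direction is favoured. The estimated step is a 1.0-fold lower number from compound 3 to compound 4 (0.02 log units; within the scatter). For compound 4 the estimated value is 5 ug/mL, with an expected range from 3 ug/mL to 8.5 ug/mL.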

Compound 4, concentration for half-maximal effect: 2.6 ug/mL
For compound 4 the middle estimate is 1.9-fold (0.28 log units) above the measured one, outside the stated range (below it).
By their numbers in this assay, from the lowest: compounds 4, 1, 2 and 3 (each within the scatter of the next).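

Working from this assay, vinyl in place of methyl on an aromatic carbon, ortho to a large group, gives a 2.0-fold lower number from compound 3 to compound 4 (0.30 log units; within the scatter) and shows that this position takes a second carbon and a double bond outside the aromatic ring without a step beyond the scatter. The comparisons with the other two compounds read a 2.0-fold lower number from compound 2 to compound 4 (0.29 log units; within the scatter) and a 1.6-fold lower number from compound 1 to compound 4 (0.20 log units; within the scatter) and stay within the scatter as well, although the steps to compound 4 from compound 2 and compound 3 are wider than any step among the three earlier compounds, so the series still shows no clear sensitivity to changes on this aromatic ring. No measurement at hand bears on why compound 4 reads as it does.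

Open, on these data alone, is whether a larger or differently built group at this place, such as a longer chain, an amine or a carboxylic acid, would produce a step beyond the scatter in this assay or would stay as flat as the methyl and vinyl pair. Also open, as far as these compounds go, is whether 2-vinylphenyl would keep the same standing against 2-methylphenyl on repeated measurement, since this one step is still within the scatter.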